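Replacing Acetyl with Methyl on the Aryl Ring

The source may hold more compounds than are shown below. What is called first, only, known or untested is meant among the compounds shown, and "the series" means these compounds.

The measured compounds, all tested in a functional assay on OVCAR-3 cells (Homo sapiens) for inhibition, read by MTT assay, with a stated time of 24 h; on this read-out higher numbers stand for weaker inhibition and lower numbers for stronger inhibition:
Compound 1, `Cc1cccc(C)c1/C=C/[C@@H]1CCCCN1`, gives 6.27 ug/mL.
Compound 2, `COc1ccccc1/C=C/[C@@H]1CCCCN1`, gives 4.78 ug/mL.
Compound 3, `CC(=O)c1ccc(/C=C/[C@@H]2CCCCN2)cc1`, gives 2.18 ug/mL.

Compound 3 stands lowest of the three numbers in this assay. Its nearest neighbour is compound 2, whose number is higher by a margin beyond the scatter, and furthest from it is compound 1, whose number is higher still, also beyond the scatter. Going by the values given here, no two of the measured compounds differ in only one place, so no single step between them has been measured.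

Compound 4, `Cc1ccc(/C=C/[C@@H]2CCCCN2)cc1`, differs from compound 3 in one place: methyl in place of acetyl on an aromatic carbon. Both compounds that lack the acetyl group, compound 1 and compound 2, give higher numbers than compound 3, so the expectation is that compound 4 moves in the same direction. The step from compound 3 to compound 4 in this assay is estimated at a 2.3-fold higher number from compound 3 to compound 4 (0.36 log units; beyond the scatter), a rise beyond the scatter. Compound 4 is therefore expected to give about 5 ug/mL in this assay, within a range from 2.5 ug/mL to 10 ug/mL.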

Compound 4, half-maximal inhibitory concentration: 8.48 ug/mL
For compound 4 the middle estimate is 1.7-fold (0.23 log units) below the measured one; the range from low to high includes it.
By their numbers in this assay, from the lowest: compound 3; then compounds 2, 1 and 4 (each within the scatter of the next).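

In this assay, the aromatic carbon para to a group of 8 heavy atoms now has a measured response to a single change: methyl in place of acetyl brings a 3.9-fold higher number from compound 3 to compound 4 (0.59 log units; beyond the scatter) and this lies beyond the scatter. Going by these compounds alone, it is the only step here between two compounds that differ in one place, which the earlier compounds could not provide. Compound 3 keeps the lower number against a partner that differs only in this group, but nothing available bears on why the step has this size.

From the compounds shown here alone, whether the carbonyl or the whole acetyl group goes with the lower number stays open. The compounds shown also do not tell how an amide, a nitrile or a carboxylic acid at this place would read.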